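A few compounds are considered here, and "the series" means these few. Any claim that something is new, unique, unknown or untested is made for them only; others in the source may bear on it.

Compound 1 `O=C(NCc1cc(Cl)ccc1-n1cnnn1)[C@@H]1C[C@@H]2C[C@@H]2N1C(=O)[C@H](O)CC1CC1` sits at the low end of the numbers in an ADME assay on liver for metabolic stability, with Liver microsome (Homo sapiens) as the target, read by LC-MS, using microsomes; on this read-out lower numbers stand for slow clearance and higher numbers for fast clearance. In this assay compound 1 gives < 12 mL.min-1.g-1, which is a limit of the assay and not a number. It stands at the limit of < 12 mL.min-1.g-1 in this assay, at which 1 of the 3 values shown sits. Compound 2 `CC(C)(C)OC[C@@H](O)C(=O)N1[C@H](C(=O)NCc2cc(Cl)ccc2-n2cnnn2)C[C@@H]2C[C@@H]21` gives 21 mL.min-1.g-1, and compound 3 `O=C(NCc1cc(Cl)ccc1-n1cnnn1)[C@@H]1C[C@@H]2C[C@@H]2N1C(=O)[C@H](O)C1CCCCC1` gives 150 mL.min-1.g-1.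

Compound 4 `O=C(NCc1cc(Cl)ccc1-n1cnnn1)[C@@H]1C[C@H]2C[C@H]2N1C(=O)[C@H](O)CC1CC1` is built from the same pieces as compound 1: the two compounds have the same atoms and bonds and differ only in configuration as drawn: 2 of 4 stereo elements differ; a stereocentre at a saturated ring carbon is drawn S in compound 1 and R in compound 4; a stereocentre at a saturated ring carbon is drawn S in compound 1 and R in compound 4. Going by the values given here, no measured step here makes a change of this kind. All three alter the side chain instead, so they bear on it only indirectly. They are an at least 1.7-fold higher number from compound 1 to compound 2 (0.24 log units; that floor lies within the scatter), then an at least 12-fold higher number from compound 1 to compound 3 (1.09 log units; beyond the scatter), and a 7.1-fold higher number from compound 2 to compound 3 (0.85 log units; beyond the scatter). These steps show how far the numbers can move with the side chain, but they say nothing about configuration. No step beyond the scatter is therefore expected in this assay, and no direction can be argued. The estimated change is an at least 1.0-fold higher number from compound 1 to compound 4 (0.03 log units; that floor lies within the scatter). For compound 4 the expected value is 13 mL.min-1.g-1, with an estimated range from 6 mL.min-1.g-1 to 40 mL.min-1.g-1.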

Compound 4, intrinsic clearance in microsomes: 25 mL.min-1.g-1
Compound 4: the middle estimate sits 1.9-fold (0.28 log units) below what was measured; the measured number falls inside the stated range.
By their numbers in this assay, from the lowest: compounds 2 and 4 (each within the scatter of the next); then compound 3. At a limit, below all of these: compound 1.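

In this assay, redrawing two saturated ring carbons from S to R, with the side chain unchanged, gives an at least 2.0-fold higher number from compound 1 to compound 4 (0.31 log units; beyond the scatter). This is the first step shown that alters the configuration of the core and not the side chain, so the number can rise with no atom or bond replaced: the fact that compounds 1 and 4 differ only in the configuration as drawn. The size of this step is only a floor, since compound 1 has a limit and not a number: the limit of < 12 mL.min-1.g-1 in this assay, at which 1 of the 4 values shown sits.

On these data alone, the two ring carbons change together, so it remains open whether one of them alone would move the number, or whether the same redrawing would do so with the side chains of compound 2 and compound 3. As far as these compounds go, how a side chain ending in an amine or a carboxylic acid would read on either configuration of the core also remains open.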